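Fluoro for chloro when only limits are known

A few compounds are considered here, and "the series" means these few. Any claim that something is new, unique, unknown or untested is made for them only; others in the source may bear on it.

Compound 1 (`O=C(CSc1nc(Cc2c(F)cccc2Cl)cc(=O)[nH]1)c1ccc(F)cc1`), compound 2 (`CCc1c(Cc2c(F)cccc2Cl)nc(SCC(=O)c2ccc(F)cc2)[nH]c1=O`) and compound 3 (`CC(C)c1c(Cc2c(F)cccc2Cl)nc(SCC(=O)c2ccc(F)cc2)[nH]c1=O`) were tested in an ADME assay on MT4 cells (Homo sapiens) for cytotoxicity, read by MTT assay (a lower number here means that less compound is tolerated, a higher number that more compound is tolerated), and none returned a number. Compound 1 gave > 61000 nM as a limit. Compound 2 gave > 57000 nM as a limit. Compound 3 stands at > 56000 nM which is likewise only a limit. Compound 4 (`CC(C)c1c(Cc2c(F)cccc2F)nc(SCC(=O)c2ccc(F)cc2)[nH]c1=O`) differs from compound 3 by fluoro in place of chloro on an aromatic carbon. The steps a step that the two limits leave unreadable from compound 1 to compound 2 and a step that the two limits leave unreadable from compound 1 to compound 3 and a step that the two limits leave unreadable from compound 2 to compound 3 all change another place and cannot be sized, so they offer no size to carry over. In this assay the expected size is a step that the limit leaves unreadable from compound 3 to compound 4 and no step beyond the scatter is expected. Compound 4 is estimated at 58000 nM with an expected range from 30000 nM to 100000 nM as its bounds.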

Compound 4, half-maximal cytotoxic concentration: > 58000 nM
Compound 4: only a limit was reported; the forecaster's own chance of this, stated with the estimate: 80%; the middle value sits exactly at the limit.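

Compound 3 and compound 4 each gave only a limit in this assay, so no size can be read for the step between them. The compounds shown leave open what concentration of compound 1, compound 2, compound 3 or compound 4 is actually cytotoxic to these cells.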